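The compounds below may be only part of what the source reports. "The series", "measured", "known", "first", "only" and "open" are said of these compounds alone.

Measured compounds:
- Compound 1, `c1ccc(Sc2ncnc3[nH]cnc23)cc1` — compound 1 gives 0% in an assay on isolated protein for inhibition of Ca2+/calmodulin-dependent protein kinase II (CaM kinase II) (Rattus norvegicus), tested at 30 uM; on this read-out lower numbers stand for less inhibition and higher numbers for more inhibition at the one concentration tested (going by the name of the read-out)
- Compound 2, `Fc1ccc(Sc2ncnc3[nH]cnc23)cc1` — compound 2 gives 0% in this assay

Both measured compounds share the same core and differ only in one place on the outer ring, a fluoro in place of hydrogen on an aromatic carbon. That single measured step, no change at the digits printed from compound 1 to compound 2 (within the scatter), left the read-out where it was, and so compound 1 stands level with compound 2 in this assay; neither shows any inhibition at the one concentration tested.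

Compound 3, `Cn1cnc2c(Sc3ccccc3)ncnc21`, is the compound still to be measured. It differs from compound 1 by methyl in place of hydrogen on an aromatic nitrogen. Among the measured compounds shown here, no measured step touches that ring nitrogen; the only step known, from compound 1 to compound 2, concerns a different place and was flat. For the measured compounds named here, with both measured compounds at the floor of the read-out and no step of any size to draw on, the expected change from compound 1 to compound 3 in this assay is no change at the digits printed from compound 1 to compound 3 (within the scatter), that is, nothing beyond the scatter. Compound 3 is therefore estimated at 0%, with a range from 0% to 15%.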

Compound 3, a percentage reported as inhibition, at one concentration (the size of the read-out at that concentration, not a potency): 8%
The estimate for compound 3 lay 8 percentage points below the measured number; low and high end bracket the measured number.
By their numbers in this assay, from the lowest: compounds 1, 2 and 3 (each within the scatter of the next).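

Methyl in place of hydrogen on the aromatic nitrogen gives a number 8 percentage points higher from compound 1 to compound 3 (within the scatter) in this assay, so this is the first look at the ring nitrogen, a different place from the outer ring touched by the fluoro step. Since compound 1 gives 0%, the read-out has no room to show any loss of inhibition, and the result says only that this methyl brings no inhibition that can be told apart from the scatter; it cannot say whether the hydrogen on that nitrogen matters for inhibition. Nothing measured here offers an explanation for the number seen with compound 3.

From the compounds shown here alone, it remains open whether a larger group on this nitrogen, such as a benzyl group or a longer chain ending in an amine or a carboxylic acid, would lift inhibition clearly beyond the scatter. Also open, going by these compounds, is what other groups on the outer ring would do, for example a methoxy group or a nitrile in place of the fluoro of compound 2, alone or together with the methyl of compound 3.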